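The compounds below may be only part of what the source reports. "The series", "measured", "known", "first", "only" and "open" are said of these compounds alone.

Compound 1 `CCCNc1ccc(S(=O)(=O)Nc2onc(C)c2C)cc1` — 27000 nM
Compound 2 `Cc1onc(NS(=O)(=O)c2cccc3c(N(C)C)cccc23)c1C` — 60 nM
Compound 3 `Cc1noc(NS(=O)(=O)c2cccc3c(NC(=O)C(C)C)cccc23)c1C` — 880 nM

All three compounds were tested in an assay on VSM-A10 cells for antagonist activity at Endothelin-1 receptor (Rattus norvegicus); on this read-out lower numbers stand for stronger inhibition and higher numbers for weaker inhibition. Compound 3 gives 880 nM, the second highest of the three numbers. Its nearest neighbour is compound 2 with 60 nM, a gap that lies beyond the usual scatter of the measurement; compound 1 with 27000 nM is the furthest away, also beyond the scatter. Compound 3 thus sits between a clearly stronger and a clearly weaker compound.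

Compound 4 `Cc1noc(NS(=O)(=O)c2cccc3c(NCc4ccccc4)cccc23)c1C` has not yet been measured. It differs from compound 3 in one place: benzyl in place of isopropylcarbonyl on a nitrogen on an aromatic ring. Among the compounds with values here, no pair of measured compounds shows this same change, so the size of the effect is open. Compound 2, whose nitrogen on the aromatic ring bears no carbonyl, gives 60 nM, which points toward a lower number for compound 4 than for compound 3. The expected step from compound 3 to compound 4 is a 4.4-fold lower number from compound 3 to compound 4 (0.64 log units; beyond the scatter), an improvement beyond the scatter. Compound 4 is therefore expected to give about 200 nM, with a likely range from 50 nM to 800 nM.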

Compound 4, half-maximal inhibitory concentration: 590 nM
Compound 4: the middle estimate sits 3.0-fold (0.47 log units) below what was measured, and the stated range covers the measured number.
By their numbers in this assay, from the lowest: compound 2; then compounds 4 and 3 (each within the scatter of the next); then compound 1.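

In this assay the change from isopropylcarbonyl to benzyl on a nitrogen on an aromatic ring gives a 1.5-fold lower number from compound 3 to compound 4 (0.17 log units; within the scatter) and so cannot be told apart from no change at all. This position therefore accepts two quite different groups with no readable shift in the number: one holds a carbonyl and no ring, and the other holds a six-membered aromatic ring of carbon only and no carbonyl. Nothing available here explains why the two groups read alike.

Still open, as far as these compounds go, is how a longer chain, such as phenylethyl, or a bare amine with no added group on that nitrogen would read in this assay at this position. Also open, from the compounds shown here alone, is whether a carboxylic acid added to the benzyl group would move the number beyond the scatter.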